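Methoxy in Place of Hydrogen on Compound 3

The source may hold more compounds than are shown below. What is called first, only, known or untested is meant among the compounds shown, and "the series" means these compounds.

Compound 1 `O=C(Nc1ccc(Sc2nc3ccccc3s2)c(Cl)c1)c1cc(Br)cc(Br)c1`: > 100000 nM
Compound 2 `O=C(Nc1ccc(Sc2nc3ccccc3s2)c(Cl)c1)c1cccc(Br)c1O`: 6900 nM
Compound 3 `O=C(Nc1ccc(Sc2nc3ccccc3s2)c(Cl)c1)c1cccc(Br)c1`: > 100000 nM

In an assay for inhibition of HSP60/HSP10 (Homo sapiens), with a stated time of 60 min (on this read-out higher numbers stand for weaker inhibition and lower numbers for stronger inhibition), compound 3 reaches only a limit, > 100000 nM. Compound 1 sits at the same limit, > 100000 nM, so two of the three values are limits (the limit of > 100000 nM in this assay, at which 2 of the 3 values shown sit). Only compound 2 gives a number, 6900 nM. The step of an at least 14-fold higher number from compound 2 to compound 3 (1.16 log units; beyond the scatter) shows how much is lost when the hydroxy is removed. Compound 4 `COc1c(Br)cccc1C(=O)Nc1ccc(Sc2nc3ccccc3s2)c(Cl)c1` differs from compound 3 by methoxy in place of hydrogen on an aromatic carbon. A methoxy is not a hydroxy, so the reverse of an at least 14-fold higher number from compound 2 to compound 3 (1.16 log units; beyond the scatter) is not expected in full; a smaller gain in this assay, an at least 1.6-fold lower number from compound 3 to compound 4 (0.22 log units; that floor lies within the scatter), is expected instead. Compound 4 is therefore estimated at 60000 nM, between 8000 nM and 300000 nM.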

Compound 4, half-maximal inhibitory concentration: > 100000 nM
Compound 4 was reported as a limit (the forecaster's own chance of this, stated with the estimate: 55%); at least 1.6-fold (0.22 log units) between middle value and limit.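

In this assay, methyl in place of hydrogen on the oxygen gives an at least 14-fold higher number from compound 2 to compound 4 (1.16 log units; beyond the scatter), so at this position an oxygen alone does not keep the measurable inhibition of compound 2; the free hydroxy is what the compounds shown link to it. The steps from compound 1 and from compound 3 to compound 4 cannot be read, as both ends are limits. Compound 4 joins the compounds that stop at a limit: the limit of > 100000 nM in this assay, at which 3 of the 4 values shown sit.

As far as these compounds go, whether an amine or a carboxylic acid in place of the hydroxy would keep inhibition stays open. From the compounds shown here alone, how far compound 4 lies beyond its limit also stays open.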